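Methoxy for Chloro on a Hydroxy-Bearing Core

The compounds below may be only part of what the source reports. "The series", "measured", "known", "first", "only" and "open" are said of these compounds alone.

Compound 1 `Fc1cccc(Nc2nc3nonc3nc2Nc2ccccc2F)c1` gives 190 nM in an assay on mitochondria from L6 cells (Rattus norvegicus) for activation, with a stated time of 90 min; a higher number here means that more compound is needed for the effect, a lower number that less compound is needed.
Compound 2 `Oc1nc2nonc2nc1Nc1ccccc1F` gives 12500 nM in this assay.
Compound 3 `Oc1nc2nonc2nc1Nc1ccc(OC(F)(F)F)cc1Cl` gives 1400 nM in this assay.

Compound 3 stands second highest of these three numbers: compound 1 is its nearest neighbour, compound 2 its furthest. Within the data shown here, the only step between two measured compounds that differ in one place is a 66-fold higher number from compound 1 to compound 2 (1.82 log units; beyond the scatter), and it describes a change at a different position from the one in question here. Compound 4 `COc1cc(OC(F)(F)F)ccc1Nc1nc2nonc2nc1O` differs from compound 3 by methoxy in place of chloro on an aromatic carbon. Among the measured compounds shown here, no measured pair shows this exchange, so the scale of its effect in this assay is not documented; the change leaves the core and the trifluoromethoxy group untouched, and a step of modest size, in either direction, is the most that is expected. Compound 4 is therefore expected to give about 1500 nM in this assay, within 500 nM to 4500 nM, a step of a 1.1-fold higher number from compound 3 to compound 4 (0.03 log units; within the scatter) that may well sit inside the scatter.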

Compound 4, half-maximal effective concentration: 3800 nM
Compound 4: middle estimate off by 2.5-fold (0.40 log units), on the low side; the range from low to high includes it.
By their numbers in this assay, from the lowest: compound 1; then compound 3; then compound 4; then compound 2.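

On an aromatic carbon ortho to a large group and meta to a trifluoromethoxy group, the exchange of chloro for methoxy gives a 2.7-fold higher number from compound 3 to compound 4 (0.43 log units; beyond the scatter) in this assay. This gives a first measured size for this change and shows that the position is not indifferent to it: chloro goes with the lower number, though a single pair on one core sets no general rule. No supporting measurement on hand accounts for the rise, so its cause remains unknown.

The compounds shown leave open how a methyl group, a fluorine atom or a plain hydrogen on this carbon would compare with chloro and methoxy. They also leave open whether the same exchange gives a step of similar size when the hydroxy on the core is replaced by the (3-fluorophenyl)amino group.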